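This account rests on a few compounds, and the source may have more. Where it says the series, first, only, none or still open, it means among the compounds named here.

Compound 3 `Cc1cccc(Cn2c(CN3CCN(C(=O)C(C)C)CC3)nc3ccccc32)c1` stands highest of the three compounds measured in an assay on isolated protein for inhibition of aldehyde dehydrogenase 1A1 (Homo sapiens), read by spectrophotometry, tested at 10 uM (a higher number here means more inhibition at the concentration tested (going by the name of the read-out), a lower number less inhibition), at 87.2%; compound 1 `Cc1cccc(Cn2c(CN3CCN(C(=O)C4CCCC4)CC3)nc3ccccc32)c1` gives 67.5% and compound 2 `Cc1cccc(Cn2c(CN3CCN(C(=O)c4ccncc4)CC3)nc3ccccc32)c1` gives 20.6%. Compound 4 `Cc1cccc(Cn2c(CN3CCN(C(=O)c4ccc(F)cc4)CC3)nc3ccccc32)c1` is not yet measured; the change from compound 3 is 4-fluorophenyl in place of isopropyl on a carbonyl carbon. Among the compounds with values here, two measured steps bear on exchanging isopropyl or cyclopentyl for a six-membered aromatic ring on the carbonyl carbon: a number 46.9 percentage points lower from compound 1 to compound 2 (beyond the scatter) and, in the reverse sense, a number 66.6 percentage points higher from compound 2 to compound 3 (beyond the scatter); by contrast a number 19.7 percentage points higher from compound 1 to compound 3 (beyond the scatter) was modest. Only compound 2 carries an aromatic ring at this carbonyl carbon, so the size is uncertain, but a large fall in this assay is expected for compound 4, a number 47.2 percentage points lower from compound 3 to compound 4 (beyond the scatter). Compound 4 is therefore estimated at 40%, with a range of 15% to 70%.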

Compound 4, a percentage reported as inhibition, at one concentration (the size of the read-out at that concentration, not a potency): 27.1%
Compound 4: middle estimate off by 12.9 percentage points, on the high side; the range from low to high includes it.
By their numbers in this assay, from the lowest: compounds 2 and 4 (each within the scatter of the next); then compound 1; then compound 3.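

In this assay the fall seen with pyridin-4-yl recurs with 4-fluorophenyl, a ring of carbon only: a number 60.1 percentage points lower from compound 3 to compound 4 (beyond the scatter) and a number 40.4 percentage points lower from compound 1 to compound 4 (beyond the scatter). The exchange between the two aromatic rings stays small, a number 6.5 percentage points higher from compound 2 to compound 4 (within the scatter), so here the loss does not depend on which of these two rings is present. Across these four compounds, the two aromatic groups on the carbonyl carbon read low and isopropyl and cyclopentyl read higher, with no compound against this; nothing available explains it. Open, as far as these compounds go, is where an unsubstituted phenyl would fall, and whether a tert-butyl or a methyl on the carbonyl carbon would match compound 3.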